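Swapping the amine on the amide side chain

This account rests on a few compounds, and the source may have more. Where it says the series, first, only, none or still open, it means among the compounds named here.

Compound 2 `COc1ccc(-c2cc3ccc(OC)cc3nc2Nc2ccc(NC(=O)CN3CCCCC3)cc2)cc1`: 47900 nM
Compound 1 `CCN(CC)CC(=O)Nc1ccc(Nc2nc3cc(OC)ccc3cc2-c2ccc(OC)cc2)cc1`: 17300 nM

In a functional assay on MCF7 cells (Homo sapiens) for antiproliferative activity, read by MTT assay, with a stated time of 48 h (a higher number here means a weaker inhibitor, a lower number a stronger inhibitor), compound 2 gives the highest number of the two, with compound 1 the nearest at 17300 nM. Compound 3 `COc1ccc(-c2cc3ccc(OC)cc3nc2Nc2ccc(NC(=O)CN3CCN(C)CC3)cc2)cc1` differs from compound 2 by 4-methylpiperazin-1-yl in place of piperidin-1-yl on a saturated chain carbon bound to a carbonyl carbon. For the measured compounds named here, the only measured step, a 2.8-fold higher number from compound 1 to compound 2 (0.44 log units; beyond the scatter), changed the same position and was modest. Going by the values given here, no step shows a piperazine directly, so a change within or near the scatter is expected in this assay, in either direction. Compound 3 is therefore estimated at 40000 nM, between 15000 nM and 120000 nM, implying a 1.2-fold lower number from compound 2 to compound 3 (0.08 log units; within the scatter).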

Compound 3, half-maximal inhibitory concentration: 2800 nM
Compound 3: middle estimate off by 14-fold (1.15 log units), on the high side; the whole stated range lies above it.
By their numbers in this assay, from the lowest: compound 3; then compound 1; then compound 2.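

In this assay the amine on this side chain matters far more than the earlier pair suggested: 4-methylpiperazin-1-yl gives a 17-fold lower number from compound 2 to compound 3 (1.23 log units; beyond the scatter) against piperidin-1-yl and a 6.2-fold lower number from compound 1 to compound 3 (0.79 log units; beyond the scatter) against diethylamino. Piperidin-1-yl and 4-methylpiperazin-1-yl are both six-membered non-aromatic rings, so a ring alone does not set the number, as the second ring nitrogen with its methyl group goes with the large drop. Nothing available here explains why this change has so large an effect.

Going by these compounds, whether the methyl group matters remains open. So does how piperazin-1-yl without that methyl, or morpholin-4-yl, would compare at this position.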